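Side-chain exchange at the amino-ester position of the series

The source may report more compounds than this note shows. Statements on the series, on what has been measured and on what is new or still open speak of the compounds shown alone.

Measured so far:
compound 1, `C[C@@H](O)[C@H](NC(=O)CN(c1nc(Cl)nc2[nH]cnc12)C1CC1)C(=O)OCc1ccccc1`, 29.7% in a functional assay on the whole organism (Tail, strain ICR) with Mus musculus as the target, in the tail flick test, with a stated time of 60 min, at a dose of 25 umol/kg by the oral route; on this read-out lower numbers stand for a weaker effect and higher numbers for a stronger effect at the one dose given
compound 2, `O=C(CN(c1nc(Cl)nc2[nH]cnc12)C1CC1)N[C@@H](CCC(=O)OCc1ccccc1)C(=O)OCc1ccccc1`, 53.7% in this assay
compound 3, `CSCC[C@H](NC(=O)CN(c1nc(Cl)nc2[nH]cnc12)C1CC1)C(=O)OCc1ccccc1`, 30.8% in this assay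

Compound 3 stands second highest of the three numbers. Its gap to compound 1, a number 1.1 percentage points higher from compound 1 to compound 3 (within the scatter), lies within the scatter, so the two are not told apart. Within the data shown here, the only step beyond the scatter is carried by the benzyloxycarbonyl chain: a number 24 percentage points higher from compound 1 to compound 2 (beyond the scatter) and a number 22.9 percentage points lower from compound 2 to compound 3 (beyond the scatter).

Compound 4 is `NC(=O)C[C@H](NC(=O)CN(c1nc(Cl)nc2[nH]cnc12)C1CC1)C(=O)OCc1ccccc1`. It differs from compound 3 in one place: carbamoyl in place of (methylsulfanyl)methyl on a saturated chain carbon, two bonds along the chain from an amide-type nitrogen and a carbonyl carbon. The two steps that bear on this change are the side-chain exchanges at the same carbon, one within the scatter and one beyond it as set out above. Among the measured compounds shown here, neither of the new groups resembles the benzyloxycarbonyl chain that alone moved the number; the exchange of hydroxyl-bearing for methylsulfanyl-bearing chain gave no step. The expectation for compound 4 is therefore a step of no more than the scatter in this assay, a number 0.2 percentage points higher from compound 3 to compound 4 (within the scatter). Compound 4 is estimated at 31%, with a range from 16% to 48%.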

Compound 4, a percentage reported as activity, at one dose (the size of the read-out at that dose, not a potency): 36.4%
Estimate against measurement, compound 4: 5.4 percentage points below, and the stated range covers the measured number.
By their numbers in this assay, from the lowest: compounds 1, 3 and 4 (each within the scatter of the next); then compound 2.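

In this assay, carbamoyl at this carbon cannot be told apart from the earlier chains without the benzyl ester, with a number 5.6 percentage points higher from compound 3 to compound 4 (within the scatter) and a number 6.7 percentage points higher from compound 1 to compound 4 (within the scatter) as its two steps. A hydrogen-bond donor on the entering group, absent from the (methylsulfanyl)methyl it replaces, therefore comes with no step beyond the scatter, while the separation of the benzyloxycarbonyl chain holds against this new group too, at a number 17.3 percentage points lower from compound 2 to compound 4 (beyond the scatter) as the step. No measurement here accounts for these results.

On these data alone, it remains open whether the step to compound 2 follows the benzyl ester itself or the whole 2-(benzyloxycarbonyl)ethyl chain. A free carboxylic acid on the same chain, or a benzyl amide in place of the ester, would separate those two readings.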